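Chloro replaces phenyl on the pendant ring of compound 3

This account rests on a few compounds, and the source may have more. Where it says the series, first, only, none or still open, it means among the compounds named here.

Measured compounds:
Compound 1 `Nc1[nH]c(C(=O)c2ccccc2)c(-c2cccc(Cl)c2)c1C(=O)c1cccc(Cl)c1` — > 100000 nM
Compound 2 `Nc1[nH]c(C(=O)c2ccccc2)c(-c2ccccc2Cl)c1C(=O)c1cccc(Cl)c1` — > 100000 nM
Compound 3 `Nc1[nH]c(C(=O)c2ccccc2)c(-c2ccc(-c3ccccc3)cc2)c1C(=O)c1cccc(Cl)c1` — > 100000 nM

In an assay for inhibition of Polyunsaturated fatty acid lipoxygenase ALOX15 (Homo sapiens), with a stated time of 10 min (a lower number here means a stronger inhibitor, a higher number a weaker inhibitor), compound 1 gives > 100000 nM, which is a limit of the assay and not a number. In this assay compound 2 gives > 100000 nM, again a limit. Compound 3 likewise gives > 100000 nM, a limit. For the measured compounds named here, the one measured step, a step that the two limits leave unreadable from compound 1 to compound 2, cannot be read in size, as the limit of > 100000 nM in this assay, at which 3 of the 3 values shown sit, shows, and compound 3 stands at that same limit, so its place on the numbers is known only as a limit.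

Compound 4 `Nc1[nH]c(C(=O)c2ccccc2)c(-c2ccc(Cl)cc2)c1C(=O)c1cccc(Cl)c1` is formed from compound 3 by chloro in place of phenyl on an aromatic carbon. Going by the values given here, no measured step bears on this change: the step from compound 1 to compound 2 concerns a different chlorophenyl, and its size is unreadable. With every shown value at the limit, compound 4 is expected to remain at or near it, so the estimated step of a number no higher from compound 3 to compound 4 (the limit leaves the size open) is none beyond the scatter. For compound 4 the estimate in this assay is 100000 nM, between 40000 nM and 300000 nM.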

Compound 4, half-maximal inhibitory concentration: > 100000 nM
Compound 4 ended at the assay's limit; the forecaster's own chance of this, stated with the estimate: 80%; the middle value sits exactly at the limit.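

In this assay, the steps to compound 4 from compound 1, compound 2 and compound 3 cannot be read in size, as all four compounds stand at one limit: the limit of > 100000 nM in this assay, at which 4 of the 4 values shown sit.

The compounds shown leave open whether any change on the pendant ring would give a value that can be read as a number.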